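Fluorine on the anilino ring of a tricyclic quinone

The compounds below may be only part of what the source reports. "The series", "measured", "known", "first", "only" and "open" are said of these compounds alone.

Compound 1 `COc1cccc(NC2=CC(=O)c3c(nc4n3[C@H]3OC[C@@H](O)[C@H]3OC4)C2=O)c1`: 1790 nM
Compound 2 `Cc1ccc(NC2=CC(=O)c3c(nc4n3[C@H]3OC[C@@H](O)[C@H]3OC4)C2=O)cc1C`: 1050 nM
Compound 3 `O=C1C=C(Nc2ccccc2)C(=O)c2c1nc1n2[C@H]2OC[C@@H](O)[C@H]2OC1`: 1730 nM

Of the compounds shown here, three sharing one core have been measured in a functional assay on MGC-803 cells (Homo sapiens) for inhibition, read by sulforhodamine B assay; on this read-out higher numbers stand for weaker inhibition and lower numbers for stronger inhibition. Compound 3 `O=C1C=C(Nc2ccccc2)C(=O)c2c1nc1n2[C@H]2OC[C@@H](O)[C@H]2OC1` gives 1730 nM, the second highest of the three numbers; its nearest neighbour is compound 1 with 1790 nM, its furthest compound 2 with 1050 nM, and both gaps lie within the scatter, so the three values cannot be told apart.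

Compound 4 `O=C1C=C(Nc2ccccc2F)C(=O)c2c1nc1n2[C@H]2OC[C@@H](O)[C@H]2OC1` is not yet measured. It differs from compound 3 by fluoro in place of hydrogen on an aromatic carbon, that is, phenyl to 2-fluorophenyl on the anilino group.

For the measured compounds named here, only one measured step changes the same aryl ring: a 1.7-fold lower number from compound 1 to compound 2 (0.23 log units; within the scatter). Swapping substituents on that ring has therefore moved the number no further than the scatter, and nothing among the measured compounds points to fluoro behaving differently. For compound 4 the expected step is a 1.2-fold lower number from compound 3 to compound 4 (0.06 log units; within the scatter), nothing beyond the scatter. Compound 4 is thus estimated at 1500 nM in this assay, with a range from 700 nM to 3500 nM.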

Compound 4, half-maximal inhibitory concentration: 2080 nM
Beside the measured number, compound 4's estimate is 1.4-fold (0.14 log units) below it; the range from low to high includes it.
By their numbers in this assay, from the lowest: compounds 2, 3, 1 and 4 (each within the scatter of the next).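

In this assay, fluoro in place of hydrogen on an aromatic carbon, ortho to a large group, gives a 1.2-fold higher number from compound 3 to compound 4 (0.08 log units; within the scatter). The earlier compounds shown here showed only one substituent pattern exchanged for another, whereas this pair adds a single fluorine to the unsubstituted phenyl of compound 3, and at this place that change leaves the number within the scatter. No evidence is available that bears on this result.

As far as these compounds go, it remains open whether a chloro, a trifluoromethyl or a carboxylic acid at this same place would move the number beyond the scatter. From the compounds shown here alone, it is equally open whether fluoro elsewhere on the ring would leave the number within the scatter, as 2-fluorophenyl does here.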